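This account rests on a few compounds, and the source may have more. Where it says the series, first, only, none or still open, it means among the compounds named here.

Working notes on the pyrazine hydrazone series. In an ADME assay on J774 cells (Mus musculus) for cytotoxicity, read by MTT assay, with a stated time of 48 h, tested at 50 ug/mL (on this read-out lower numbers stand for a stronger effect and higher numbers for a weaker effect at the one concentration tested), compound 1 `O=C(N/N=C/c1ccccc1F)c1cnccn1` gives 100% and compound 3 `O=C(N/N=C/c1ccc(Br)cc1)c1cnccn1` gives 100%. Compound 2 `O=C(N/N=C/c1cccc(F)c1)c1cnccn1` gives 49% in this assay and so stands lowest of the three numbers, with compound 1 and compound 3 both higher by a margin beyond the scatter.

Compound 4 `O=C(N/N=C/c1cccc(O)c1)c1cnccn1` differs from compound 2 by hydroxy in place of fluoro on an aromatic carbon. For the measured compounds named here, no measured pair shows this exchange, so no step can be drawn from the data. The low number rests on compound 2 alone, while compound 1 and compound 3 sit at the top of the range. The step from the two to the new compound is expected to be a rise of a number 31 percentage points higher from compound 2 to compound 4 (beyond the scatter), with wide uncertainty. The estimate for compound 4 in this assay is 80%, within a range from 45% to 100%.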

Compound 4, a percentage reported as activity, at one concentration (the size of the read-out at that concentration, not a potency): 100%
The estimate for compound 4 lay 20 percentage points below the measured number, within the range that was stated.
By their numbers in this assay, from the lowest: compound 2; then compounds 1, 3 and 4 (each within the scatter of the next).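

In this assay, for the compounds shown here, hydroxy in place of fluoro on an aromatic carbon, meta to a large group, gives a number 51 percentage points higher from compound 2 to compound 4 (beyond the scatter) and is the first single exchange that can be read. The low number of compound 2 therefore does not belong to the shared core alone, but depends on the group at this place. Nothing measured on these compounds gives a reason for the step. As far as these compounds go, whether an amine or a methoxy group at this place would give a low number like that of compound 2 stays open.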